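Methyl at the saturated ring carbon across two cores

A few compounds are considered here, and "the series" means these few. Any claim that something is new, unique, unknown or untested is made for them only; others in the source may bear on it.

Measured compounds:
compound 1, `O=C1NC(=O)/C(=C/C2=Cc3cc(Br)ccc3OC2)S1`, 79500 nM
compound 2, `O=C1NC(=O)/C(=C/C2=Cc3cc(Br)ccc3OC2)N1`, 19300 nM
compound 3, `CC1Oc2ccc(Br)cc2C=C1/C=C1\SC(=O)NC1=O`, 65500 nM

The series is read in a functional assay on A549 cells (Homo sapiens) for antiproliferative activity, read by MTT assay, with a stated time of 72 h; on this read-out higher numbers stand for weaker inhibition and lower numbers for stronger inhibition. Compound 1 and compound 3 share one core; compound 3 carries the change methyl in place of hydrogen on a saturated ring carbon relative to compound 1. The step from that change, a 1.2-fold lower number from compound 1 to compound 3 (0.08 log units; within the scatter), is small and lies within the scatter, so nothing can be said about its direction.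

Compound 2 stands on a second core. How the core of compound 2 differs from the core of compound 1 is not broken down here. What the numbers show is that compound 2 gives the lowest value of the three, with compound 3 and compound 1 both beyond the scatter above it.

Compound 4, `CC1Oc2ccc(Br)cc2C=C1/C=C1\NC(=O)NC1=O`, is not yet measured. It relates to compound 2 exactly as compound 3 relates to compound 1: the change is methyl in place of hydrogen on a saturated ring carbon, and the place is described in the same words for both pairs, so this is the same change on a different core. On the first core the step was a 1.2-fold lower number from compound 1 to compound 3 (0.08 log units; within the scatter). Among the measured compounds shown here, with no other pair of the same change available, the expectation for compound 4 rests on that single step alone: the step from compound 2 to compound 4 is expected to be about as small, a 1.1-fold lower number from compound 2 to compound 4 (0.06 log units; within the scatter), in this assay. Compound 4 is therefore estimated at 17000 nM in this assay, with a range from 8000 nM to 38000 nM that allows for the scatter and for the change falling differently on the second core, of which nothing is known.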

Compound 4, half-maximal inhibitory concentration: 17500 nM
Beside the measured number, compound 4's estimate is 1.0-fold (0.01 log units) below it, and the stated range covers the measured number.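

In this assay, methyl in place of hydrogen on a saturated ring carbon, next to the ring oxygen, gives a 1.1-fold lower number from compound 2 to compound 4 (0.04 log units; within the scatter), so no difference can be read on this core. Set beside the step on the other core, the result is the same small step, with no readable gap between the two: the same change on two cores in this assay, a 1.2-fold lower number (0.08 log units; within the scatter) from compound 1 to compound 3 and a 1.1-fold lower number (0.04 log units; within the scatter) from compound 2 to compound 4, 1.1-fold (0.04 log units) apart, within the scatter of two such steps. This shows that, for these two pairs, the change carries from one core to the other without a readable shift in the antiproliferative read-out, but with both steps inside the scatter, it gives no direction for the methyl, says nothing about the difference between the cores, and rests on two pairs in a single assay, so it sets no rule for further cores or for other places on the ring.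

Going by these compounds, only hydrogen and methyl appear at this ring carbon, so it remains open whether a longer chain such as propyl, or a group such as an amine or a carboxylic acid, would also leave the number unmoved on either core. On these data alone, it also remains open whether the agreement between the two cores would hold for such groups, or in cells other than those of this assay.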